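A few compounds are considered here, and "the series" means these few. Any claim that something is new, unique, unknown or untested is made for them only; others in the source may bear on it.

Measured compounds in a functional assay on A549 cells (Homo sapiens) for inhibition, read by CCK-8 assay, with a stated time of 72 h, tested at 10 uM; a higher number here means a stronger effect of the compound at the concentration tested, a lower number a weaker effect:
compound 1 `CN(C)C(=O)c1cc2cnc(Nc3ccc(C(=O)NCCCCCN=C=S)cc3)nc2n1C1CCCC1` gives 100%
compound 2 `CN(C)C(=O)c1cc2cnc(Nc3ccc(C(=O)NCCCCCCN=C=S)cc3)nc2n1C1CCCC1` gives 100%
compound 3 `CN(C)C(=O)c1cc2cnc(Nc3ccc(NC(=O)CCCCN=C=S)cc3)nc2n1C1CCCC1` gives 102%

Compound 3 holds the highest of the three numbers, yet a number 2 percentage points higher from compound 1 to compound 3 (within the scatter) and a number 2 percentage points higher from compound 2 to compound 3 (within the scatter) both lie within the scatter, so no ranking among the three can be read from this assay; each sits at essentially complete inhibition at the concentration tested.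

Compound 4 `CN(C)C(=O)c1cc2cnc(Nc3ccc(NC(=O)CCCCCCN=C=S)cc3)nc2n1C1CCCC1` has not yet been measured. It differs from compound 3 by a group of 5 heavy atoms (3 carbon, 1 nitrogen, 1 sulfur; no ring) in place of a group of 3 heavy atoms (1 carbon, 1 nitrogen, 1 sulfur; no ring), on a saturated chain carbon, four bonds along the chain from a carbonyl carbon. In plain terms the chain on the carbonyl side of the amide is lengthened while everything else is kept.

The measured step that bears most directly on this is no change at the digits printed from compound 1 to compound 2 (within the scatter), where the corresponding chain on the nitrogen side of the amide was lengthened in the same way and nothing moved. The two steps to compound 3, which combine a change of chain length with a reversal of the amide, were likewise within the scatter. Nothing in the series therefore points to any effect of chain length on this read-out at the concentration tested.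

Compound 4 is accordingly expected to give 100%, with a range of 90% to 108%. The expected step is a number 2 percentage points lower from compound 3 to compound 4 (within the scatter), that is, none beyond the scatter.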

Compound 4, a percentage reported as inhibition, at one concentration (the size of the read-out at that concentration, not a potency): 102%
For compound 4 the middle estimate is 2 percentage points below the measured one; low and high end bracket the measured number.
By their numbers in this assay, from the lowest: compounds 1, 2, 3 and 4 (each within the scatter of the next).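

In this assay, for the compounds shown here, lengthening the chain on the carbonyl side of the amide, at the saturated chain carbon four bonds along the chain from a carbonyl carbon, gives no change at the digits printed from compound 3 to compound 4 (within the scatter) and so adds a chain-length step on this side of the amide to the one earlier seen only on the nitrogen side. Against the compounds with the amide the other way round, the comparisons give a number 2 percentage points higher from compound 2 to compound 4 (within the scatter) and a number 2 percentage points higher from compound 1 to compound 4 (within the scatter) and thus extend the flat picture to all four compounds, each at essentially complete inhibition at the one concentration tested, with neither chain length nor amide direction separating them. No available evidence accounts for this flat read-out.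

The compounds shown leave open whether a longer chain, or an amine or a carboxylic acid in place of the isothiocyanate at the chain end, would bring the inhibition down from this level. They also leave open whether the four compounds would differ at lower concentrations, since a reading at a single concentration gives the size of the effect there and not a potency.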